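Dithiocarbamate triazoles: three limits, one further analogue

The source may hold more compounds than are shown below. What is called first, only, known or untested is meant among the compounds shown, and "the series" means these compounds.

Measured so far in a functional assay on ECa-109 cells (Homo sapiens) for inhibition, read by MTT assay, with a stated time of 72 h; on this read-out higher numbers stand for weaker inhibition and lower numbers for stronger inhibition:
Compound 1, `CC(C)(C)OC(=O)N1CCN(C(=S)SCc2cn(-c3ccccc3F)nn2)CC1`, returns only a limit of the assay, > 128000 nM.
Compound 2, `Cc1cc(=O)oc2cc(OCCn3cc(CSC(=S)N4CCN(C(=O)OC(C)(C)C)CC4)nn3)ccc12`, likewise returns only a limit, > 128000 nM.
Compound 3, `S=C(SCc1cn(Cc2ccc(Cl)c(Cl)c2)nn1)N1CCNCC1`, also returns only a limit, > 128000 nM.

Compound 1 cannot be placed on the numbers shown: its value is a limit, not a number, and the other two values are limits as well, so no ordering among the three compounds is possible. the limit of > 128000 nM in this assay, at which 3 of the 3 values shown sit, sums up the whole measured set. Going by the values given here, no step between measured compounds is available, since the structures differ in more than one place.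

Compound 4, `COc1ccc(Cn2cc(CSC(=S)N3CCN(C(=O)OC(C)(C)C)CC3)nn2)cc1`, is the next to be measured in this assay. Relative to compound 1 the change is 4-methoxybenzyl in place of 2-fluorophenyl on an aromatic nitrogen. Among the compounds with values here, with every measured value a limit, there is no measured step to lean on. The expected step in this assay is a step that the limit leaves unreadable from compound 1 to compound 4, none beyond the scatter, with a limit again the most likely outcome. For compound 4 the estimate in this assay is 150000 nM, ranging from 60000 nM to 400000 nM.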

Compound 4, half-maximal inhibitory concentration: 36800 nM
Beside the measured number, compound 4's estimate is 4.1-fold (0.61 log units) above it, and the stated range ends above it.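

In this assay, going by these compounds alone, 4-methoxybenzyl in place of 2-fluorophenyl on an aromatic nitrogen gives an at least 3.4-fold lower number from compound 1 to compound 4 (0.54 log units; beyond the scatter), the first readable step. The size of this step is only a bound, as compound 1 has a limit and not a number, but it does show that the group at this position can bring the read-out within the measurable range. Compound 4 is also the only compound here with a number, while the rest of the set stays at a single value: the limit of > 128000 nM in this assay, at which 3 of the 4 values shown sit.

The entering group differs from the leaving one in both its substituent and its size, so the two changes cannot be told apart on this step. From the compounds shown here alone, a plain benzyl or a 4-methoxyphenyl at the same nitrogen would separate them, and whether a 4-aminobenzyl or a longer chain to the methoxyphenyl ring carries the same step remains open.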